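The source may hold more compounds than are shown below. What is called first, only, known or untested is meant among the compounds shown, and "the series" means these compounds.

Three compounds carry the shared core. Compound 1 `COc1ccc(-c2cc(/C=C/C(=O)c3ccc(N)cc3)[nH]n2)cc1` gives 8250 nM in a functional assay on SF-539 cells (Homo sapiens) for inhibition, read by sulforhodamine B assay, with a stated time of 48 h; a lower number here means that less compound is tolerated, a higher number that more compound is tolerated. Compound 2 `COc1cc(-c2cc(/C=C/C(=O)c3ccc(N)cc3)[nH]n2)cc(OC)c1OC` gives 5420 nM, and the other two lie within the scatter of it: compound 3 `COc1ccc(C(=O)/C=C/c2cc(-c3cc(OC)c(OC)c(OC)c3)n[nH]2)cc1` gives 5850 nM, and compound 1 stands a little further off. Within the data shown here, the only single step known, a 1.1-fold higher number from compound 2 to compound 3 (0.03 log units; within the scatter), concerns a methoxy in place of amino on the aromatic carbon of the other ring. Compound 4 `COc1ccc(-c2cc(/C=C/C(=O)c3ccc(N)cc3)[nH]n2)cc1OC` differs from compound 2 by hydrogen in place of methoxy on an aromatic carbon. Among the measured compounds shown here, no measured step removes a methoxy, so compound 3 gives only indirect guidance; the expected step is a 1.0-fold higher number from compound 2 to compound 4 (0.01 log units; within the scatter), nothing beyond the scatter. Compound 4 is therefore estimated at 5500 nM, between 2500 nM and 12000 nM.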

Compound 4, concentration lethal to 50% of the cells: 7190 nM
The estimate for compound 4 lay 1.3-fold (0.12 log units) below the measured number; low and high end bracket the measured number.
By their numbers in this assay, from the lowest: compounds 2, 3, 4 and 1 (each within the scatter of the next).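

In this assay, taking away the methoxy that sits ortho to a methoxy group and meta to a large group gives a 1.3-fold higher number from compound 2 to compound 4 (0.12 log units; within the scatter), while adding a methoxy to the same ring gives a 1.1-fold lower number from compound 1 to compound 4 (0.06 log units; within the scatter). Both steps lie within the scatter, so these first changes on the methoxy-bearing ring, where the earlier step concerned the other ring, leave the number effectively unmoved. No evidence on the cause of these results is available. As far as these compounds go, whether a hydroxyl or an amine on this aromatic carbon would move the number beyond the scatter remains open.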